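Swapping 4-fluorophenyl for phenylsulfonyl's plain phenyl

This account rests on a few compounds, and the source may have more. Where it says the series, first, only, none or still open, it means among the compounds named here.

In a functional assay on KB cells (Homo sapiens) for cytotoxicity (on this read-out lower numbers stand for stronger inhibition and higher numbers for weaker inhibition), compound 2 `COc1ccc(S(=O)(=O)N2CCc3cccc(NS(=O)(=O)c4ccc(F)cc4)c32)cc1` gives 1200 nM, the highest of the three measured numbers. Compound 1 `COc1ccc(S(=O)(=O)N2CCc3cccc(NC(=O)C(C)(C)C)c32)cc1` gives 359 nM and compound 3 `COc1ccc(S(=O)(=O)N2CCc3cccc(NC(=O)c4ccccc4)c32)cc1` gives 297 nM, two values within the scatter of each other. Compound 4 `COc1ccc(S(=O)(=O)N2CCc3cccc(NS(=O)(=O)c4ccccc4)c32)cc1` differs from compound 2 by one change: hydrogen in place of fluoro on an aromatic carbon. The nearest measured steps, a 3.3-fold higher number from compound 1 to compound 2 (0.52 log units; beyond the scatter) and a 4.0-fold lower number from compound 2 to compound 3 (0.61 log units; beyond the scatter), are modest, yet each replaces the whole group on the nitrogen, and a 1.2-fold lower number from compound 1 to compound 3 (0.08 log units; within the scatter) stays within the scatter. None of them tests the loss of fluoro, so the expectation starts from compound 2 at 1200 nM. No step beyond the scatter is expected from this change. The expected change is a 1.2-fold lower number from compound 2 to compound 4 (0.08 log units; within the scatter). Compound 4 is estimated at 1000 nM, with an expected range of 450 nM to 2200 nM.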

Compound 4, half-maximal inhibitory concentration: 650 nM
Beside the measured number, compound 4's estimate is 1.5-fold (0.19 log units) above it; low and high end bracket the measured number.
By their numbers in this assay, from the lowest: compounds 3, 1, 4 and 2 (each within the scatter of the next, the first and the last beyond it).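

In this assay, hydrogen in place of fluoro para to a large group gives a 1.8-fold lower number from compound 2 to compound 4 (0.27 log units; within the scatter), so removing this fluoro leaves the number within the scatter. With the fluoro gone, the phenylsulfonyl group still separates from benzoyl, at a 2.2-fold higher number from compound 3 to compound 4 (0.34 log units; beyond the scatter), but not from (tert-butyl)carbonyl, at a 1.8-fold higher number from compound 1 to compound 4 (0.26 log units; within the scatter), and so the sulfonyl compounds do not stand clearly apart from both amides. Nothing available explains these steps. The compounds shown leave open how a chloro or methoxy group at this aromatic carbon would read, and how an amine on the phenyl ring would compare.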